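The compounds below may be only part of what the source reports. "The series", "measured", "known", "first", "only" and "open" are said of these compounds alone.

Compound 1, `CCOC(=O)c1csc2nc(CN3CCN(C)CC3)c(-c3ccc(C)cc3)n12`: 53600 nM. Compound 2, `CCOC(=O)c1csc2nc(CN3CCN(C)CC3)c(-c3ccc(OC)cc3)n12`: 68400 nM. Compound 3, `CC(=O)NNC(=O)c1csc2ncc(-c3ccc(C)cc3)n12`: 63600 nM.

All three were tested in a functional assay on HepG2 cells (Homo sapiens) for antiproliferative activity, read by MTT assay, with a stated time of 72 h; a higher number here means a weaker inhibitor, a lower number a stronger inhibitor. Compound 1 and compound 2 share one core and differ only by methoxy in place of methyl on an aromatic carbon; the step of a 1.3-fold higher number from compound 1 to compound 2 (0.11 log units; within the scatter). Compound 3 carries a different core, and the difference between the two cores is not broken down here. Compound 4, `COc1ccc(-c2cnc3scc(C(=O)NNC(C)=O)n23)cc1`, is not yet measured; it differs from compound 3 by methoxy in place of methyl on an aromatic carbon, the same change as that from compound 1 to compound 2, at the same place. Because the measured step of a 1.3-fold higher number from compound 1 to compound 2 (0.11 log units; within the scatter) is small, the step of a 1.2-fold higher number from compound 3 to compound 4 (0.07 log units; within the scatter) is expected to be small as well. Compound 4 is therefore estimated at 75000 nM in this assay, with a likely range from 35000 nM to 160000 nM.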

Compound 4, half-maximal inhibitory concentration: 11800 nM
Estimate against measurement, compound 4: 6.4-fold (0.80 log units) above, outside the stated range (below it).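

In this assay, methoxy in place of methyl did not act alike on the two cores: the same change on two cores in this assay, a 1.3-fold higher number (0.11 log units; within the scatter) from compound 1 to compound 2 and a 5.4-fold lower number (0.73 log units; beyond the scatter) from compound 3 to compound 4, 6.9-fold (0.84 log units) apart, beyond the scatter of two such steps. The new step, a 5.4-fold lower number from compound 3 to compound 4 (0.73 log units; beyond the scatter), stands well apart from the earlier one, a 1.3-fold higher number from compound 1 to compound 2 (0.11 log units; within the scatter), so a step read on one core in this series cannot simply be carried to the other. This rests on two pairs only, and the cores differ in more than one part, so the data do not show which part of them sets the size of the step, nor how the change would act on any further core. The compounds shown leave open whether a chlorine atom or an ethoxy group at the same place would also give a lower number on the core of compound 3. They also leave open whether adding the methylpiperazine side chain of compound 1 to that core would remove the gap between the two steps.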